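Fluoro in place of isopropyl on the amide-bearing ring

The source may report more compounds than this note shows. Statements on the series, on what has been measured and on what is new or still open speak of the compounds shown alone.

Compound 2 `Cc1nc(Cc2cccc(C(F)(F)F)c2)sc1-c1ccc(C(N)=O)c(C(C)C)c1` was tested in a functional assay on cells for agonist activity at G-protein coupled receptor 52 (Homo sapiens), read by AlphaScreen and cAMP accumulation, with a stated time of 30 min (on this read-out lower numbers stand for an effect already at smaller amounts and higher numbers for an effect only at larger amounts of compound), where compound 2 gives 370 nM. Within the data shown here, its only neighbour among the measured compounds is compound 1 `Cc1nc(Cc2cccc(C(F)(F)F)c2)sc1-c1ccc(C(N)=O)cc1`, which in this assay gives 220 nM; the step of a 1.7-fold higher number from compound 1 to compound 2 (0.23 log units; within the scatter) shows that the two values are indistinguishable. Compound 3 `Cc1nc(Cc2cccc(C(F)(F)F)c2)sc1-c1ccc(C(N)=O)c(F)c1` differs from compound 2 by fluoro in place of isopropyl on an aromatic carbon. Since a 1.7-fold higher number from compound 1 to compound 2 (0.23 log units; within the scatter) stayed within the scatter when a group of three carbons was added at this carbon, a group of one fluorine there is expected to change little, with the step of a 1.4-fold lower number from compound 2 to compound 3 (0.15 log units; within the scatter) expected to stay within the scatter. Compound 3 is therefore estimated at 260 nM, within 120 nM to 600 nM.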

Compound 3, half-maximal effective concentration: 380 nM
Estimate against measurement, compound 3: 1.5-fold (0.16 log units) below; low and high end bracket the measured number.
By their numbers in this assay, from the lowest: compounds 1, 2 and 3 (each within the scatter of the next).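

Fluoro for isopropyl, 1 heavy atom for 3, gives a 1.0-fold higher number from compound 2 to compound 3 (0.01 log units; within the scatter), and fluoro for hydrogen gives a 1.7-fold higher number from compound 1 to compound 3 (0.24 log units; within the scatter), so all three compounds read alike with hydrogen, fluoro or isopropyl on this aromatic carbon. Among these three groups, the number of heavy atoms at this carbon makes no difference that can be read. Nothing measured here explains this. As far as these compounds go, whether an amine or a carboxylic acid on this carbon would also stay within the scatter remains open, and the same holds for a longer chain.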